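Swapping a hydroxyphenyl for pyridinyl at the benzyloxy arm

The source may report more compounds than this note shows. Statements on the series, on what has been measured and on what is new or still open speak of the compounds shown alone.

Compound 1 `NC(=O)Cc1cc(=O)oc2cc(OCc3cccc(F)c3)ccc12`: 50 nM
Compound 2 `NC(=O)Cc1cc(=O)oc2cc(OCc3cccc(O)c3)ccc12`: 1000 nM

In an assay for inhibition of Amine oxidase [flavin-containing] B (Rattus norvegicus) (on this read-out lower numbers stand for stronger inhibition and higher numbers for weaker inhibition), compound 2 gives the highest of the two numbers measured, with compound 1 as its nearest neighbour at a value lower by a 20-fold higher number from compound 1 to compound 2 (1.30 log units; beyond the scatter). Compound 3 `NC(=O)Cc1cc(=O)oc2cc(OCc3cccnc3)ccc12` carries the change (pyridin-3-yl in place of 3-hydroxyphenyl on a saturated chain carbon bound to an oxygen on an aromatic ring). For the measured compounds named here, only the step from compound 1 to compound 2 bears on this position, and it was large; no measured pair shows the loss of the hydroxy group alone. With the hydroxy gone and an acceptor retained, a step is expected in a 3.3-fold lower number from compound 2 to compound 3 (0.52 log units; beyond the scatter) toward a lower number, but of uncertain size. Compound 3 is expected to give 300 nM, within 80 nM to 1500 nM.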

Compound 3, half-maximal inhibitory concentration: 1300 nM
Compound 3: the middle estimate sits 4.3-fold (0.64 log units) below what was measured; measured number inside the range.
By their numbers in this assay, from the lowest: compound 1; then compounds 2 and 3 (each within the scatter of the next).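

In this assay, swapping 3-hydroxyphenyl for pyridin-3-yl leaves the result within the scatter, with a 1.3-fold higher number from compound 2 to compound 3 (0.11 log units; within the scatter) (so the two groups cannot be told apart here). Losing the hydrogen-bond donor while keeping an acceptor therefore does not recover the stronger inhibition seen with 3-fluorophenyl, which stays well apart, with a 26-fold higher number from compound 1 to compound 3 (1.41 log units; beyond the scatter) (a large step). Nothing measured here explains why this arm tolerates fluoro so much better. Still open, from the compounds shown here alone, is where an unsubstituted phenyl, a 3-chlorophenyl or a 3-methoxyphenyl would fall on this arm.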